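This account rests on a few compounds, and the source may have more. Where it says the series, first, only, none or still open, it means among the compounds named here.

Measured compounds:
compound 1 `O=C(COc1ccc2c(=O)ccoc2c1)Nc1cccc(NC(=O)c2ccccc2)c1` gives 16 nM in an assay on isolated protein for inhibition of Rho-associated protein kinase 2 (Homo sapiens), read by scintillation counting, radiometric assay and 33P incorporation, with a stated time of 40 min, in the presence of a further agent that is not named here; a lower number here means a stronger inhibitor, a higher number a weaker inhibitor;
compound 2 `Cc1ccc(C(=O)Nc2cccc(NC(=O)COc3ccc4c(=O)ccoc4c3)c2)cc1` gives 22 nM in this assay;
compound 3 `COc1ccc(C(=O)Nc2cccc(NC(=O)COc3ccc4c(=O)ccoc4c3)c2)cc1` gives 7 nM in this assay.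

Compound 3 stands lowest of the three numbers, and both of its steps to the others lie beyond the scatter: a 2.3-fold lower number from compound 1 to compound 3 (0.36 log units; beyond the scatter) and a 3.1-fold lower number from compound 2 to compound 3 (0.50 log units; beyond the scatter). It is therefore the strongest inhibitor of the measured set. The third measured step, a 1.4-fold higher number from compound 1 to compound 2 (0.14 log units; within the scatter), shows that methyl in place of hydrogen on that aromatic carbon made no difference the assay could resolve.

Compound 4 `Cc1cc(C(=O)Nc2cccc(NC(=O)COc3ccc4c(=O)ccoc4c3)c2)ccc1C(F)(F)F` differs from compound 3 in one place: a group of 11 heavy atoms (8 carbon, 3 fluorine; one six-membered aromatic ring of carbon only) in place of a group of 8 heavy atoms (7 carbon, 1 oxygen; one six-membered aromatic ring of carbon only), on a carbonyl carbon. The entering group carries fluorine and no oxygen, so the 4-methoxyphenyl that gave compound 3 its advantage is gone. For the measured compounds named here, the steps that bear on this are the two gains obtained by bringing in methoxy, a 2.3-fold lower number from compound 1 to compound 3 (0.36 log units; beyond the scatter) and a 3.1-fold lower number from compound 2 to compound 3 (0.50 log units; beyond the scatter); removing it should give back that gain, while the methyl and the fluorinated part have no measured precedent here, since the only methyl step, a 1.4-fold higher number from compound 1 to compound 2 (0.14 log units; within the scatter), was within the scatter. Compound 4 is therefore expected to show a higher number in this assay than compound 3, a modest step of roughly a 5.0-fold higher number from compound 3 to compound 4 (0.70 log units; beyond the scatter), landing near compound 1 and compound 2 but with wide uncertainty. The estimate for compound 4 is 35 nM, within a range from 12 nM to 110 nM.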

Compound 4, half-maximal inhibitory concentration: 43 nM
Compound 4: middle estimate off by 1.2-fold (0.09 log units), on the low side, within the range that was stated.
By their numbers in this assay, from the lowest: compound 3; then compounds 1, 2 and 4 (each within the scatter of the next, the first and the last beyond it).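

In this assay the place on the carbonyl carbon accepts the larger fluorinated group without losing activity altogether, but the advantage of the 4-methoxyphenyl does not carry over: the change is a 6.1-fold higher number from compound 3 to compound 4 (0.79 log units; beyond the scatter) and is the largest step seen so far in the series. Set against the plain phenyl of compound 1, the same entering group is also resolved by the assay (here a 2.7-fold higher number from compound 1 to compound 4 (0.43 log units; beyond the scatter) is the step), whereas against the methyl-bearing ring of compound 2 the step of a 2.0-fold higher number from compound 2 to compound 4 (0.29 log units; within the scatter) stays within the scatter, so only the comparison with compound 2 fails to separate the new group from an earlier one. No measurement shown here explains these differences.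

Methoxy left and methyl and trifluoromethyl entered together in compound 4, so the compounds shown leave open how much of the step belongs to each change, and a phenyl ring carrying trifluoromethyl alone or methoxy together with trifluoromethyl would be needed to separate them. They also leave open how this place would respond to a ring carrying an amine or a carboxylic acid, or to a longer chain in place of the ring.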